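Extending the Amide Linker in Compound 2 toward Compound 3

The source may report more compounds than this note shows. Statements on the series, on what has been measured and on what is new or still open speak of the compounds shown alone.

Measured compounds:
compound 1, `Nc1ccccc1NC(=O)/C=C/c1ccc(COCNc2nc(Nc3cccc(Cl)c3)c3ncn(C4CCCC4)c3n2)cc1`: 9.19%
compound 2, `CC(C)n1cnc2c(Nc3cccc(Cl)c3)nc(NCOCc3ccc(C(=O)Nc4ccccc4N)cc3)nc21`: 63.4%

In a functional assay on HCT-116 cells (Homo sapiens) for antiproliferative activity, read by CCK-8 assay, with a stated time of 72 h, tested at 8 uM (a lower number here means a weaker effect, a higher number a stronger effect of the compound at the concentration tested), compound 2 gives 63.4%, the higher of the two numbers. Compound 1 lies far below it, a gap beyond the usual scatter, but the two structures differ in more than one place, so no single step can be read from them. Compound 3, `CC(C)n1cnc2c(Nc3cccc(Cl)c3)nc(NCOCc3ccc(/C=C/C(=O)Nc4ccccc4N)cc3)nc21`, differs from compound 2 in one place only: 2-((2-aminophenyl)carbamoyl)ethenyl in place of (2-aminophenyl)carbamoyl on an aromatic carbon. Compound 1, which carries the same ethenyl-containing group on a core that differs elsewhere, gives 9.19%. Because compound 1 shows 9.19% with that group, a step downward beyond the scatter is expected for a number 28.4 percentage points lower from compound 2 to compound 3 (beyond the scatter). Compound 3 is therefore estimated at 35% in this assay. The expected range for compound 3 runs from 10% to 60%.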

Compound 3, a percentage reported as inhibition, at one concentration (the size of the read-out at that concentration, not a potency): 27.9%
Estimate against measurement, compound 3: 7.1 percentage points above, and the stated range covers the measured number.
By their numbers in this assay, from the lowest: compound 1; then compound 3; then compound 2.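

In this assay, replacing (2-aminophenyl)carbamoyl with 2-((2-aminophenyl)carbamoyl)ethenyl on the aromatic carbon para to a large group gives a number 35.5 percentage points lower from compound 2 to compound 3 (beyond the scatter) and so shows that the read-out is sensitive to this change on the core shared by these two compounds. With the ethenyl-containing group held the same, isopropyl in place of cyclopentyl on the aromatic nitrogen gives a number 18.7 percentage points higher from compound 1 to compound 3 (beyond the scatter) and so separates a contribution of that nitrogen substituent, which the two earlier compounds, differing in more than one place, could not show. The compounds shown leave open how an ethyl linker in place of the ethenyl unit, or a methyl or cyclobutyl group on the aromatic nitrogen, would read at the same concentration. On these data alone, it also remains open whether the step from (2-aminophenyl)carbamoyl to the ethenyl-containing group has the same size with cyclopentyl on that nitrogen. No measurement offered here explains either step.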